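Phenyl for Chloro on the Anilide of Compound 1

A few compounds are considered here, and "the series" means these few. Any claim that something is new, unique, unknown or untested is made for them only; others in the source may bear on it.

Measured compounds:
Compound 1 `O=C(CCCCCCNC(=O)C(O)(O)C(F)(F)F)Nc1ccc(Cl)cc1`: 260000 nM
Compound 2 `O=C(CCCCCCNC(=O)C(O)(O)C(F)(F)F)Nc1ncc(-c2ccc(O)cc2)s1`: 210000 nM
Compound 3 `COc1ccc(-c2cnc(NC(=O)CCCCCCNC(=O)C(O)(O)C(F)(F)F)s2)cc1`: 37000 nM

In an assay on isolated protein for inhibition of protein deacetylase HDAC6 (Homo sapiens), read by chemiluminescence, with a stated time of 3 h (a higher number here means a weaker inhibitor, a lower number a stronger inhibitor), compound 1 gives the highest of the three numbers. Compound 2 stands nearest to it, with a gap that lies within the scatter, so the two cannot be ranked. For the measured compounds named here, compound 3 lies furthest away; its number is clearly lower than that of compound 1, though the two differ in more than one place and no single step connects them. Going by the values given here, the one step that is measured, a 5.7-fold lower number from compound 2 to compound 3 (0.75 log units; beyond the scatter), concerns a methyl in place of hydrogen on an oxygen on an aromatic ring and does not touch the position altered here.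

Compound 4 `O=C(CCCCCCNC(=O)C(O)(O)C(F)(F)F)Nc1ccc(-c2ccccc2)cc1` differs from compound 1 by phenyl in place of chloro on an aromatic carbon. Among the compounds with values here, no measured step bears directly on this change. What the data do show is that compound 3, the one with an aromatic ring carrying a methyl on oxygen, has the lowest number, while compound 1 with a chloro has the highest. On that footing a modest fall is expected, a 2.2-fold lower number from compound 1 to compound 4 (0.34 log units; beyond the scatter), with a wide range. Compound 4 is therefore estimated at 120000 nM, between 35000 nM and 300000 nM.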

Compound 4, half-maximal inhibitory concentration: 38000 nM
Compound 4: middle estimate off by 3.2-fold (0.50 log units), on the high side; the measured number falls inside the stated range.
By their numbers in this assay, from the lowest: compounds 3 and 4 (each within the scatter of the next); then compounds 2 and 1 (each within the scatter of the next).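

For the compounds shown here, until this result, the only measured step lay on an oxygen on an aromatic ring, so nothing showed whether the position on the aromatic carbon, para to a large group, responds to a change at all. It does respond in this assay: phenyl in place of chloro gives a 6.8-fold lower number from compound 1 to compound 4 (0.84 log units; beyond the scatter), a modest step but one that lies beyond the scatter, so this position is not indifferent to the group it carries. Nothing in the available data explains why the exchange of a single chlorine for a six-membered aromatic ring of carbon only lowers the number, and the step is recorded here only as an observation.

The compounds shown leave open whether the phenyl ring itself matters, or whether a cyclohexyl, a benzyl or a pyridyl group at the same place would give a similar step. They also leave open how an amine, a carboxylic acid or a methoxy group on the new phenyl of compound 4 would move the number, and whether a shorter or longer chain would change the size of this step.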